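Adding a second chloro: expected receptor displacement

The compounds below may be only part of what the source reports. "The series", "measured", "known", "first", "only" and "open" are said of these compounds alone.

Compound 1 `CC(C)Cc1csc(N)c1C(=O)c1ccc(Cl)cc1` and compound 2 `CC(C)(C)Cc1c(-c2ccccc2)sc(N)c1C(=O)c1ccccc1Cl` have both been tested in an assay on CHO cells for displacement of a labelled ligand from adenosine receptor A1 (Homo sapiens), read by scintillation counting, tested at 10 uM; on this read-out higher numbers stand for more inhibition at the one concentration tested (going by the name of the read-out) and lower numbers for less inhibition. In this assay compound 1 gives 1%, and compound 2 gives 1%. The two values are level at the digits reported and lie within the usual scatter of repeated runs, so compound 2 stands exactly where compound 1 stands; neither shows appreciable displacement at the single concentration used.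

Compound 3 `CC(C)(C)Cc1c(-c2ccccc2)sc(N)c1C(=O)c1ccc(Cl)cc1Cl` has not yet been measured in this assay. It differs from compound 2 in one place: chloro in place of hydrogen on an aromatic carbon. Cut one bond further out, the change reads 2-chlorophenyl to 2,4-dichlorophenyl; the entering chloro sits meta to the existing chloro group and para to a large group.

Within the data shown here, no step between measured compounds is available to calibrate this change, and the two measured values give only a flat baseline. The expected step is a number 1 percentage points higher from compound 2 to compound 3 (within the scatter), that is, none beyond the scatter. Compound 3 is therefore estimated at 2% in this assay, with a range from -8% to 14%.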

Compound 3, a percentage reported as inhibition, at one concentration (the size of the read-out at that concentration, not a potency): 1%
Beside the measured number, compound 3's estimate is 1 percentage points above it, and the stated range covers the measured number.
By their numbers in this assay, from the lowest: compounds 1, 2 and 3 (each within the scatter of the next).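

In this assay the change from 2-chlorophenyl to 2,4-dichlorophenyl gives no change at the digits printed from compound 2 to compound 3 (within the scatter) and provides the series' only reading of a single change, which compounds 1 and 2 could not supply because they differ in more than one place. At this position, para to a large group and meta to a chloro group, chloro in place of hydrogen on an aromatic carbon therefore brings no displacement beyond that already seen, and compound 3 stays on the same flat baseline as compound 2. No evidence bears on why this chloro leaves the read-out unmoved.

With both members of the pair this close to the bottom of the read-out, the step cannot show whether the same chloro would matter on a compound with clear displacement at the one concentration tested. Also open, as far as these compounds go, is whether a different group at this position, such as an amine, a methoxy or a carboxylic acid, would move the value in this assay away from this baseline.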